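The source may hold more compounds than are shown below. What is called first, only, known or untested is meant among the compounds shown, and "the series" means these compounds.

Measured so far:
- compound 1, `Cc1ccc(CN[C@@H]2C[C@H]3C[C@@H]([C@H]2C)C3(C)C)s1`: 780 nM
- compound 2, `C=Cc1csc(CN[C@@H]2C[C@H]3C[C@@H]([C@H]2C)C3(C)C)c1`: 6250 nM
- compound 3, `C[C@H]1[C@H](NCc2cccs2)C[C@H]2C[C@@H]1C2(C)C`: 25000 nM

These three compounds share a core and differ only on the thiophene ring. In an ADME assay on MDCK cells (Canis lupus familiaris) for cytotoxicity, read by microscopy, with a stated time of 48 h (a lower number here means that less compound is tolerated, a higher number that more compound is tolerated), compound 3 gives 25000 nM, the highest number of the three, so it is the compound of which the most is tolerated by the cells; the nearest to it is compound 2 with 6250 nM, and the furthest is compound 1 with 780 nM.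

Compound 4, `Cc1csc(CN[C@@H]2C[C@H]3C[C@@H]([C@H]2C)C3(C)C)c1`, is compound 3 with one change: methyl in place of hydrogen on an aromatic carbon. Within the data shown here, two measured steps bear on this. Removing a methyl from an aromatic carbon gave a 32-fold higher number from compound 1 to compound 3 (1.51 log units; beyond the scatter), a large step toward more tolerance. Removing a vinyl from an aromatic carbon gave a 4.0-fold higher number from compound 2 to compound 3 (0.60 log units; beyond the scatter), a more modest step in the same direction. Adding a methyl to compound 3 reverses the direction of both of these steps, so a lower number is expected for compound 4, most likely of a size between the two measured steps. The expected step is a 6.3-fold lower number from compound 3 to compound 4 (0.80 log units; beyond the scatter). Compound 4 is therefore estimated to give 4000 nM, with a likely range from 1500 nM to 12000 nM.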

Compound 4, minimum cytotoxic concentration: 12500 nM
Estimate against measurement, compound 4: 3.1-fold (0.49 log units) below; the whole stated range lies below it.
By their numbers in this assay, from the lowest: compound 1; then compounds 2, 4 and 3 (each within the scatter of the next, the first and the last beyond it).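

In this assay, a methyl on the aromatic carbon two ring bonds from the ring sulfur and two ring bonds from the ring atom that bears a large group gives a 2.0-fold lower number from compound 3 to compound 4 (0.30 log units; within the scatter), so at this place the added methyl shows no clear effect on the number. Methyl and vinyl on this same carbon give a 2.0-fold higher number from compound 2 to compound 4 (0.30 log units; within the scatter), which is also too small to separate the two groups, even though the step from compound 2 to compound 3 alone lies beyond the scatter. The sharpest new information comes from moving the methyl: going from 5-methylthiophen-2-yl to 4-methylthiophen-2-yl gives a 16-fold higher number from compound 1 to compound 4 (1.20 log units; beyond the scatter), which shows that the low number of compound 1 cannot be read as an effect of any methyl on the thiophene, since it goes with that one placement.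

These compounds leave open whether this carbon would also accept a different kind of group, such as an amine, a carboxylic acid or a longer chain like propyl. Nothing in the data given here explains why the two methyl placements differ so strongly.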